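Amide of the acid: compound 1 to compound 3

A few compounds are considered here, and "the series" means these few. Any claim that something is new, unique, unknown or untested is made for them only; others in the source may bear on it.

Compound 1 `CCCCCN(CCCCC)C(=O)N1CCN(C(=O)N(c2ccccc2)c2ccccc2)[C@H](C(=O)O)C1` gives the lower of the two numbers in an assay on CHO cells for binding affinity to Substance-P receptor (Homo sapiens) (a higher number here means a weaker inhibitor, a lower number a stronger inhibitor), at 130 nM. Its companion compound 2 `CCCCCN(CCCCC)C(=O)N1CCN(C(=O)N(c2ccccc2)c2ccccc2)[C@H](CO)C1` gives 280 nM, and the step from compound 1 to compound 2, hydroxymethyl in place of carboxy on a saturated ring carbon, reads a 2.2-fold higher number from compound 1 to compound 2 (0.33 log units; beyond the scatter). Compound 3 `CCCCCN(CCCCC)C(=O)N1CCN(C(=O)N(c2ccccc2)c2ccccc2)[C@H](C(=O)NCCCN(CC)CC)C1` carries a different change at the same place: (3-(diethylamino)propyl)amino in place of hydroxy on a carbonyl carbon. Among the measured compounds shown here, only the step to compound 2 bears on it, and it was modest, so a modest rise in the number from compound 1 to compound 3 is expected, a 2.0-fold higher number from compound 1 to compound 3 (0.30 log units; within the scatter). Compound 3 is therefore estimated at 260 nM, within 80 nM to 850 nM.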

Compound 3, half-maximal inhibitory concentration: 41 nM
For compound 3 the middle estimate is 6.3-fold (0.80 log units) above the measured one; the whole stated range lies above it.
By their numbers in this assay, from the lowest: compound 3; then compound 1; then compound 2.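

The carbonyl carbon on this saturated ring carbon accepts a long amine-bearing chain: (3-(diethylamino)propyl)amino in place of hydroxy moves the number down (a 3.2-fold lower number from compound 1 to compound 3 (0.50 log units; beyond the scatter)) in this assay, whereas the earlier change at this place moved it up. Against the hydroxymethyl compound the gap is wider (a 6.8-fold lower number from compound 2 to compound 3 (0.83 log units; beyond the scatter)), so changes here shift the number in both directions. Nothing at hand accounts for this shift.

Still open, going by these compounds, is whether the amide alone or the terminal diethylamino group drives the drop, which a plain propyl amide would separate. A shorter ethyl linker or a morpholine end would test how much of the chain matters.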